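Cyclopropyl in place of bromo on compound 3

The compounds below may be only part of what the source reports. "The series", "measured", "known", "first", "only" and "open" are said of these compounds alone.

In a physicochemical assay for lipophilicity, at pH 7.4 (a higher number here means a more lipophilic compound, a lower number a more polar compound), compound 1 `Cc1cnn(-c2ccncc2N2CCC(C(=O)N(C)C)CC2)c1` gives 1.6 and compound 2 `Cc1ccn(-c2ccncc2N2CCC(C(=O)N(C)C)CC2)n1` gives 1.5. Changing the methyl-bearing group gave a number 0.10 log units lower from compound 1 to compound 2 (within the scatter). Compound 3 `CN(C)C(=O)C1CCN(c2cnccc2-n2cc(Br)cn2)CC1` stands highest of the three at 2.1. The two steps that reach its bromo group are a number 0.50 log units higher from compound 1 to compound 3 (beyond the scatter) and a number 0.60 log units higher from compound 2 to compound 3 (beyond the scatter).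

Compound 4 `CN(C)C(=O)C1CCN(c2cnccc2-n2cc(C3CC3)cn2)CC1` carries cyclopropyl in place of bromo on an aromatic carbon. Among the measured compounds shown here, no measured compound carries cyclopropyl, so the steps to compound 3 bear on this change only indirectly. They compare bromo with methyl, not with cyclopropyl, and they suggest a modest size at most for an exchange of this kind. Starting from compound 3 at 2.1, no change beyond the scatter is expected in this assay, with a slight rise the likelier direction. The expected step is a number 0.10 log units higher from compound 3 to compound 4 (within the scatter). Compound 4 is estimated at 2.2, with an expected range from 1.9 to 2.5.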

Compound 4, distribution coefficient: 2.1
Compound 4: middle estimate off by 0.10 log units, on the high side; the range from low to high includes it.
By their numbers in this assay, from the lowest: compounds 2 and 1 (each within the scatter of the next); then compounds 3 and 4 (each within the scatter of the next).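

In this assay the step of no change at the digits printed from compound 3 to compound 4 (within the scatter) shows that, at this aromatic carbon of the five-membered ring, three carbon atoms in a three-membered ring can take the place of a single bromine with no change beyond the scatter. Cyclopropyl also stands clear of both methyl compounds, with a number 0.50 log units higher from compound 1 to compound 4 (beyond the scatter) and a number 0.60 log units higher from compound 2 to compound 4 (beyond the scatter) as the steps, so the gap first seen with bromo now appears with a second group, one built of carbon only. Nothing in the data gives a reason for these numbers.

Going by these compounds, what an amine or a carboxylic acid at this carbon would do to the number remains open. So does whether a longer chain, such as n-butyl, would stay level with bromo and cyclopropyl or move beyond them.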